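The compounds below may be only part of what the source reports. "The series", "measured", "known", "first", "only" and "open" are said of these compounds alone.

Measured so far in a functional assay on the whole organism (strain Wistar) for inhibition, with Rattus norvegicus as the target, read by paw edema, with a stated time of 6 h, at a dose of 100 mg/kg; a lower number here means less inhibition, a higher number more inhibition at the dose given (going by the name of the read-out):
compound 1 `COc1cc2c(cc1OC)C(CC(=O)Nc1ccc(Br)cc1)CC2` — 46.3%
compound 2 `COc1cc2c(cc1OC)C(CC(=O)Nc1ccc([N+](=O)[O-])cc1)CC2` — 37%

Compound 1 gives the higher of the two numbers, but the gap to compound 2, a number 9.3 percentage points lower from compound 1 to compound 2 (within the scatter), keeps the two within the scatter of this assay, so neither number can be called the higher one in any firm sense.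

Compound 3 `COc1cc2c(cc1OC)C(CC(=O)Nc1ccccn1)CC2` is not yet measured. Against compound 1 it shows (pyridin-2-yl in place of 4-bromophenyl on an amide-type nitrogen). For the measured compounds named here, no measured step touches this change: the only step on record, the one from compound 1 to compound 2, alters a substituent on the phenyl ring and stays within scatter, which says nothing about swapping the whole ring for pyridin-2-yl. Going by the values given here, with the one step available lying within scatter, no shift beyond the scatter is expected for compound 3, though the wide range reflects how little the data say. The expected step is a number 6.3 percentage points lower from compound 1 to compound 3 (within the scatter). Compound 3 is estimated at 40%, between 25% and 55%.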

Compound 3, a percentage reported as inhibition, in the whole organism at one dose (the size of the read-out at that dose, not a potency): 29.6%
Estimate against measurement, compound 3: 10.4 percentage points above; the range from low to high includes it.
By their numbers in this assay, from the lowest: compounds 3, 2 and 1 (each within the scatter of the next, the first and the last beyond it).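

Pyridin-2-yl in place of 4-bromophenyl on an amide-type nitrogen gives a number 16.7 percentage points lower from compound 1 to compound 3 (beyond the scatter) in this assay, so this position gives a step beyond the scatter, which the change on the phenyl ring, a number 9.3 percentage points lower from compound 1 to compound 2 (within the scatter), did not. The exchange removes the bromine and places a nitrogen in the aromatic ring at once, and this one step does not separate the two. No measured evidence on the cause of this step is at hand.

Open, from the compounds shown here alone, is whether an unsubstituted phenyl, pyridin-3-yl or pyridin-4-yl group on this nitrogen would stay near compound 1 or near compound 3 in this assay. Also open, going by these compounds, is what an amine or a carboxylic acid on the aromatic ring would do to this read-out.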